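A few compounds are considered here, and "the series" means these few. Any claim that something is new, unique, unknown or untested is made for them only; others in the source may bear on it.

Compound 1 `COc1ccc(CNc2nc(SC)nc3ccccc23)cc1` is the point of departure, and its standing is known only as a bound. In an ADME assay on 184B5 cells (Homo sapiens) for cytotoxicity, read by MTT assay, with a stated time of 72 h (a lower number here means a stronger inhibitor of growth, a higher number a weaker inhibitor of growth), compound 1 gives > 100000 nM, which is a limit of the assay and not a number. Compound 2 `CSc1nc(NCc2ccccc2)c2ccccc2n1` differs from it by hydrogen in place of methoxy on an aromatic carbon. In this assay compound 2 gives > 100000 nM, again a limit. The step that the two limits leave unreadable from compound 1 to compound 2 is therefore unreadable, since (the limit of > 100000 nM in this assay, at which 2 of the 2 values shown sit). Compound 3 `COc1ccc(CNc2nc(S)nc3ccccc23)cc1` has not yet been measured. Among the compounds with values here, its difference from compound 1 is hydrogen in place of methyl on a sulfur, a change that appears in no measured pair here, so no measured step bears on it. The step of a number no higher from compound 1 to compound 3 (the limit leaves the size open) is therefore expected to be none beyond the scatter, with a fair chance that only a limit is returned. Compound 3 is estimated at 100000 nM, with a range from 30000 nM to 300000 nM.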

Compound 3, concentration for total growth inhibition: 36600 nM
Compound 3: the middle estimate sits 2.7-fold (0.44 log units) above what was measured; low and high end bracket the measured number.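

In this assay, hydrogen in place of methyl on the sulfur gives an at least 2.7-fold lower number from compound 1 to compound 3 (0.43 log units; beyond the scatter), the first readable step among these compounds. Within the data shown here, the earlier step, hydrogen in place of methoxy, could not be read, so only this change shows that the number can move beyond the scatter, and it does so at the sulfur. Going by these compounds, the true size of the step remains open on one side, since compound 1 stands at a limit of the assay and not at a number: the limit of > 100000 nM in this assay, at which 2 of the 3 values shown sit.

The compounds shown do not tell whether the step belongs to the sulfanyl group itself or would also appear with an ethyl chain or an acetic acid chain on that sulfur. They also leave open what hydrogen in place of methoxy does when the sulfanyl group is present.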